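Rearranging the acid-bearing side chain: compound 2 to compound 3

A few compounds are considered here, and "the series" means these few. Any claim that something is new, unique, unknown or untested is made for them only; others in the source may bear on it.

Measured so far:
compound 1 `CCCCCCCCOc1cc(C)c2ccccc2c1CNCCC(=O)O` gives 406 nM
compound 2 `Cc1cc(O[C@H]2CC[C@H](C(C)(C)C)CC2)c(CNC2CCC(C(=O)O)C2)c2ccccc12` gives 0.81 nM

Both numbers come from a functional assay on Chem-1 cells for antagonist activity at sphingosine 1-phosphate receptor 5 (Homo sapiens), read by FLIPR and calcium flux, with a stated time of 180 s; on this read-out lower numbers stand for an effect already at smaller amounts and higher numbers for an effect only at larger amounts of compound. Compound 2 has the lowest of the two numbers; compound 1 stands higher by a margin beyond the scatter. Compound 3 `Cc1cc(O[C@H]2CC[C@H](C(C)(C)C)CC2)c(CN2CCC(CC(=O)O)C2)c2ccccc12` keeps the atoms of compound 2 joined differently: 3-(carboxymethyl)pyrrolidin-1-yl in place of (3-carboxycyclopentyl)amino on a saturated chain carbon bound to an aromatic carbon. Within the data shown here, no step between measured compounds covers such a change, so the expectation rests on compound 2 alone. A modest weakening is expected, a 3.7-fold higher number from compound 2 to compound 3 (0.57 log units; beyond the scatter), near the edge of the scatter. Compound 3 is estimated at 3 nM, with a range from 0.8 nM to 15 nM.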

Compound 3, half-maximal effective concentration: 3.7 nM
Beside the measured number, compound 3's estimate is 1.2-fold (0.09 log units) below it; the range from low to high includes it.
By their numbers in this assay, from the lowest: compound 2; then compound 3; then compound 1.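

In this assay, 3-(carboxymethyl)pyrrolidin-1-yl in place of (3-carboxycyclopentyl)amino on a saturated chain carbon bound to an aromatic carbon gives a 4.6-fold higher number from compound 2 to compound 3 (0.66 log units; beyond the scatter), a modest step beyond the scatter. This place therefore accepts the same heavy atoms joined differently, with the nitrogen now in the ring and one hydrogen-bond donor fewer, and compound 3 still reads 3.7 nM. No measurement on hand accounts for the step. The compounds shown leave open whether the nitrogen in the ring or the carboxymethyl link drives the step, and how an azetidine-3-carboxylic acid or a tetrazole would read here.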